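The source may report more compounds than this note shows. Statements on the series, on what has been measured and on what is new or still open speak of the compounds shown alone.

Of the compounds shown here, three on closely related structures have been tested in a physicochemical assay for solubility, read by chemiluminescence, measured as kinetic solubility; a higher number here means a more soluble compound, a lower number a less soluble compound: compound 1 `CC(=O)NCc1cccc(Cn2nc(NS(=O)(=O)c3ccc(Cl)s3)c3c(C(C)=O)cccc32)c1`, compound 2 `COc1c(F)ccc2c1c(NS(=O)(=O)c1ccc(Cl)s1)nn2Cc1cccc(CNC(=O)C(C)(C)O)c1` and compound 3 `COc1cccc2c1c(NS(=O)(=O)c1cccc(Cl)c1)nn2Cc1cccc(CNC(=O)C(C)(C)O)c1`. Compound 1 gives 57 ug/mL. Compound 2 reads >= 174 ug/mL, which is a limit and not a number. Compound 3 reads >= 198 ug/mL, also only a limit, and that limit is all that is known of where it stands. Compound 4 `COc1cccc2c1c(NS(=O)(=O)c1ccc(C)c(F)c1)nn2Cc1cccc(CNC(=O)C(C)(C)O)c1` has 3-fluoro-4-methylphenyl in place of 3-chlorophenyl on a sulfonyl sulfur. Among the measured compounds shown here, no measured pair differs in one place, so no direct precedent exists for this change. The expected step of an at least 1.1-fold lower number from compound 3 to compound 4 (0.04 log units; that floor lies within the scatter) in this assay is estimated to stay within the scatter, with no firm direction. Compound 4 is expected at 180 ug/mL, with an estimated range of 80 ug/mL to 240 ug/mL.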

Compound 4, solubility: 36 ug/mL
Beside the measured number, compound 4's estimate is 5.0-fold (0.70 log units) above it; measured number outside the range, below it.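

In this assay, this is the first pair among the compounds shown that differs in one place, and the aryl group on the sulfonyl sulfur alone moves the read-out beyond the scatter: 3-fluoro-4-methylphenyl in place of 3-chlorophenyl gives an at least 5.5-fold lower number from compound 3 to compound 4 (0.74 log units; beyond the scatter). Compound 3 reads >= 198 ug/mL, which is a limit.

The change swaps chlorine for fluorine and adds a methyl together, and these compounds do not separate the two. On these data alone, how a phenyl on the sulfonyl sulfur bearing an amine or a carboxylic acid would read also remains open.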